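Compound 3 and the 4-methoxy-2-nitrophenyl change

A few compounds are considered here, and "the series" means these few. Any claim that something is new, unique, unknown or untested is made for them only; others in the source may bear on it.

In a functional assay for inhibition, with Homo sapiens as the target (a lower number here means tighter binding, a higher number weaker binding), compound 3 `CC(C)(Oc1ccccc1Br)C1OCC(C/C=C\CCC(=O)O)C(c2cccnc2)O1` gives 63.1 nM and compound 2 `CC(C)(Oc1ccccc1O)C1OCC(C/C=C\CCC(=O)O)C(c2cccnc2)O1` gives 95.5 nM, a pair separated by a 1.5-fold lower number from compound 2 to compound 3 (0.18 log units; within the scatter). Compound 1 `COc1ccc(OC(C)(C)C2OCC(C/C=C\CCC(=O)O)C(c3cccnc3)O2)cc1` gives 302 nM, and the two steps away from it are a 3.2-fold lower number from compound 1 to compound 2 (0.50 log units; beyond the scatter) and a 4.8-fold lower number from compound 1 to compound 3 (0.68 log units; beyond the scatter). Compound 4 `COc1ccc(OC(C)(C)C2OCC(C/C=C\CCC(=O)O)C(c3cccnc3)O2)c([N+](=O)[O-])c1` carries 4-methoxy-2-nitrophenyl in place of 2-bromophenyl on an oxygen on a saturated carbon. The entering 4-methoxy-2-nitrophenyl echoes both the 4-methoxyphenyl of compound 1 and the 2-bromophenyl of compound 3. Going by the values given here, no measured step isolates the nitro group, so the best guide is a 4.8-fold lower number from compound 1 to compound 3 (0.68 log units; beyond the scatter), read in reverse and only in part. The expected change is a 2.2-fold higher number from compound 3 to compound 4 (0.35 log units; beyond the scatter), a modest step in this assay. Compound 4 is estimated at 140 nM, with an expected range of 50 nM to 400 nM.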

Compound 4, dissociation constant: 6.17 nM
Compound 4: middle estimate off by 23-fold (1.36 log units), on the high side, and the stated range ends above it.
By their numbers in this assay, from the lowest: compound 4; then compounds 3 and 2 (each within the scatter of the next); then compound 1.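

In this assay there is a 49-fold lower number from compound 1 to compound 4 (1.69 log units; beyond the scatter) with nitro in place of hydrogen on an aromatic carbon, so this single added group outweighs every earlier change at this position. The 4-methoxy-2-nitrophenyl also stands clearly apart from the 2-bromophenyl and 2-hydroxyphenyl groups, which had lain within the scatter of each other, with a 10-fold lower number from compound 3 to compound 4 (1.01 log units; beyond the scatter) and a 15-fold lower number from compound 2 to compound 4 (1.19 log units; beyond the scatter) as the steps to it.

From the compounds shown here alone, whether the nitro group would do the same without the methoxy group, or whether an amine or a nitrile could replace it, stays open. Nothing available explains why this group has so large an effect.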